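The source may report more compounds than this note shows. Statements on the series, on what has been measured and on what is new or still open speak of the compounds shown alone.

Measured so far:
- compound 1, `CN(C(=O)C(C)(C)C)c1ccc2[nH]c(-c3n[nH]c4ccccc34)cc2n1`: 18000 nM
- compound 2, `Cc1ccc(S(=O)(=O)N(C)c2ccc3[nH]c(-c4n[nH]c5ccccc45)cc3n2)cc1`: 13300 nM
- compound 3, `CN(c1ccc2[nH]c(-c3n[nH]c4ccccc34)cc2n1)S(=O)(=O)c1cccc([N+](=O)[O-])c1`: 13600 nM

All three share one core and differ only in the group on the methylated nitrogen of that core. In a functional assay on HCT-116 cells (Homo sapiens) for antiproliferative activity, read by MTT assay, with a stated time of 72 h (on this read-out higher numbers stand for weaker inhibition and lower numbers for stronger inhibition), compound 1 gives 18000 nM, the highest of the three numbers, but its gap to compound 3 and the step of a 1.4-fold lower number from compound 1 to compound 2 (0.13 log units; within the scatter) both lie within the scatter, so the three compounds stand level.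

Compound 4, `COc1ccc(NC(=O)N(C)c2ccc3[nH]c(-c4n[nH]c5ccccc45)cc3n2)cc1`, is not yet measured. It differs from compound 1 in one place: (4-methoxyphenyl)amino in place of tert-butyl on a carbonyl carbon.

Among the compounds with values here, two measured steps bear on this. Exchanging the whole acyl group of compound 1 for a sulfonyl group gave a 1.4-fold lower number from compound 1 to compound 2 (0.13 log units; within the scatter), and changing the aryl group on that sulfonyl gave a 1.0-fold higher number from compound 2 to compound 3 (0.01 log units; within the scatter). Neither alteration at this position moved the number beyond the scatter, and nothing here points to the new group behaving differently. Compound 4 is therefore expected to show a 1.2-fold lower number from compound 1 to compound 4 (0.08 log units; within the scatter), a step within the scatter. The estimated value of compound 4 in this assay is 15000 nM, within a range of 5000 nM to 45000 nM.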

Compound 4, half-maximal inhibitory concentration: 63 nM
Estimate against measurement, compound 4: 240-fold (2.38 log units) above, outside the stated range (below it).
By their numbers in this assay, from the lowest: compound 4; then compounds 2, 3 and 1 (each within the scatter of the next).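

In this assay the group on this carbonyl carbon turns out to matter a great deal: (4-methoxyphenyl)amino in place of tert-butyl gives a 290-fold lower number from compound 1 to compound 4 (2.46 log units; beyond the scatter) while the earlier exchanges at this site stayed within the scatter. The level numbers of compound 1, compound 2 and compound 3 therefore held only for those groups, and this position can carry a very large change. The entering group brings a hydrogen-bond donor, a hydrogen-bond acceptor and an aromatic ring that tert-butyl lacks, but no measurement here accounts for the jump or shows which of these features counts.

Still open, as far as these compounds go, is which part of the new group is needed: phenylamino would test the methoxy, methylamino the ring, and 4-methoxyphenyl directly on the carbonyl carbon the amino nitrogen. From the compounds shown here alone, whether other ring substituents, such as a chlorine atom, serve as well also remains open.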